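The compounds below may be only part of what the source reports. "The series", "measured", "known", "first", "only" and "open" are said of these compounds alone.

Of the compounds shown here, two built on a shared core have been tested in a functional assay on CHO cells for antagonist activity at adenosine receptor A2b (Homo sapiens); a lower number here means a stronger inhibitor, a higher number a weaker inhibitor. Compound 1 is `O=C(Nc1ncc(C(=O)O)c2nc(-c3ccco3)nn12)NC1CCCCC1`. In this assay compound 1 reaches only a limit of the measurement, > 30000 nM. Compound 2 is `CCOC(=O)c1cnc(NCC2CCCCC2)n2nc(-c3ccco3)nc12`. In this assay compound 2 likewise gives only a limit, > 10000 nM. Among the measured compounds shown here, both values shown are therefore limits rather than numbers, one sitting at the limit of > 10000 nM in this assay, at which 1 of the 2 values shown sits, and one at the limit of > 30000 nM in this assay, at which 1 of the 2 values shown sits, so compound 2 has no place on a measured scale and no step between measured compounds can be drawn. Compound 3, `CCOC(=O)c1cnc(NC2CCCCC2)n2nc(-c3ccco3)nc12`, differs from compound 2 by one change: cyclohexyl in place of cyclohexylmethyl on a nitrogen on an aromatic ring. With nothing measured to lean on, the expected step from compound 2 to compound 3 is a step that the limit leaves unreadable from compound 2 to compound 3, none beyond the scatter in either direction. Compound 3 is accordingly expected to give 15000 nM, between 3000 nM and 60000 nM, most likely reported once more only as a limit.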

Compound 3, inhibition constant: > 10000 nM
Compound 3: no number, only a limit; the forecaster's own chance of this, stated with the estimate: 80%; the middle value lies beyond the limit too.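

Among the compounds shown here, compound 2 and compound 3 each give only a limit in this assay, so no step from one to the other can be read: the limit of > 10000 nM in this assay, at which 2 of the 3 values shown sit.

The compounds shown leave open whether cyclohexyl in place of cyclohexylmethyl changes the inhibition at all, and what true inhibition constant any of them has.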